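Fluoro in place of nitro on a pyrimidine-like core

The compounds below may be only part of what the source reports. "The series", "measured", "known", "first", "only" and "open" are said of these compounds alone.

Measured so far:
- compound 1, `CN1CCN(c2ccc(Nc3ncc(F)c(NC4CCCC4)n3)cc2)CC1`: 29000 nM
- compound 2, `COc1cc(C(=O)NC2CCN(C)CC2)ccc1Nc1ncc(F)c(NC2CCCC2)n1`: 2100 nM
- compound 3, `CN1CCC(NC(=O)c2ccc(Nc3ncc([N+](=O)[O-])c(NC4CCCC4)n3)cc2)CC1`: 15600 nM

All three were tested in a functional assay on HCT-8 cells (Homo sapiens) for cytotoxicity, read by MTT assay, with a stated time of 48 h; on this read-out higher numbers stand for weaker inhibition and lower numbers for stronger inhibition. Compound 3 stands second highest of the three numbers; its nearest neighbour is compound 1, whose number is higher but within the scatter, so the two cannot be told apart. Compound 2 gives a number well below that of compound 3, and this gap is beyond the scatter.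

Compound 4, `CN1CCC(NC(=O)c2ccc(Nc3ncc(F)c(NC4CCCC4)n3)cc2)CC1`, is the next compound to be measured in this assay. It differs from compound 3 in one place: fluoro in place of nitro on an aromatic carbon. Compound 4 therefore shares its fluoro group with compound 1 and compound 2, and shares its amide tail with compound 3.

Among the compounds with values here, no step between measured compounds isolates this change. The fluoro-bearing compounds 1 and 2 sit on either side of compound 3, so the fluoro group alone does not fix where compound 4 will land. A modest step downward, close to the edge of the scatter, is expected from compound 3 to compound 4: a 2.0-fold lower number from compound 3 to compound 4 (0.29 log units; within the scatter). Compound 4 is estimated at 8000 nM, with a range from 2500 nM to 25000 nM.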

Compound 4, half-maximal inhibitory concentration: 16000 nM
Compound 4: middle estimate off by 2.0-fold (0.30 log units), on the low side; the measured number falls inside the stated range.
By their numbers in this assay, from the lowest: compound 2; then compounds 3, 4 and 1 (each within the scatter of the next).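

In this assay, fluoro in place of nitro, on the aromatic carbon ortho to a cyclopentylamino group, gives a 1.0-fold higher number from compound 3 to compound 4 (0.01 log units; within the scatter) and so cannot be told apart from no change, although nitro brings 3 heavy atoms and 2 hydrogen-bond acceptors while fluoro brings 1 heavy atom and none. Hydrogen in place of methoxy gives a 7.6-fold higher number from compound 2 to compound 4 (0.88 log units; beyond the scatter) and is the only one of these new steps beyond the scatter, which makes the methoxy group the single change here that separates two compounds in this assay. With (1-methylpiperidin-4-yl)carbamoyl in place of 4-methylpiperazin-1-yl, the step is a 1.8-fold lower number from compound 1 to compound 4 (0.26 log units; within the scatter) and again within the scatter, so these two tails cannot be told apart when the methoxy group is absent.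

No measurement shown explains any of these steps. Still open, from the compounds shown here alone, are how chloro, nitrile or amino would read at the nitro and fluoro position, and whether methoxy, placed as in compound 2, would shift the number of compound 3 as it does that of compound 4.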